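Compound 2 to compound 4: a change on the ester chain

This account rests on a few compounds, and the source may have more. Where it says the series, first, only, none or still open, it means among the compounds named here.

In a functional assay on HCT-116 cells (Homo sapiens) for inhibition, read by MTT assay, with a stated time of 48 h (a lower number here means a stronger inhibitor, a higher number a weaker inhibitor), compound 1 (`C[Se]c1ccc(N(C)c2nc(C3CC3)nc3ccccc23)cc1`) gives 15 nM and compound 3 (`Cc1nc(N(C)c2ccc([Se]C#N)c(C)c2)c2ccccc2n1`) gives 13 nM, two values within the scatter of each other. Compound 2 (`COc1ccc(N(C)c2nc(C)nc3ccccc23)cc1C(=O)OCC[Se]C#N`) gives 951 nM, the highest of the three numbers and beyond the scatter from both of the others. Compound 2 differs from each of them in more than one place, so that gap cannot be assigned to any single structural change.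

Compound 4 (`COc1ccc(N(C)c2nc(C)nc3ccccc23)cc1C(=O)OCCC[Se]C#N`) has not yet been measured. It differs from compound 2 by a group of 4 heavy atoms (2 carbon, 1 nitrogen, 1 selenium; no ring) in place of a group of 3 heavy atoms (1 carbon, 1 nitrogen, 1 selenium; no ring), on a saturated chain carbon, two bonds along the chain from an oxygen next to a carbonyl group, on a saturated chain carbon, two bonds along the chain from an oxygen next to a carbonyl group. Everything else in the structure is shared.

Going by the values given here, no measured pair differs in only one place, so the data offer no direct precedent for this change. Compound 2, at 951 nM, is the closest measured structure and anchors the expectation. No step beyond the scatter is expected in this assay, with a slight lean towards a lower number. The estimated step is a 1.6-fold lower number from compound 2 to compound 4 (0.20 log units; within the scatter). Compound 4 is expected at 600 nM, with an estimated range from 200 nM to 1800 nM.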

Compound 4, half-maximal inhibitory concentration: 720 nM
Compound 4: middle estimate off by 1.2-fold (0.08 log units), on the low side; the measured number falls inside the stated range.
By their numbers in this assay, from the lowest: compounds 3 and 1 (each within the scatter of the next); then compounds 4 and 2 (each within the scatter of the next).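

In this assay, going by these compounds alone, the series now has its first pair that differs in one place, and it reads as a 1.3-fold lower number from compound 2 to compound 4 (0.12 log units; within the scatter), the only direct evidence so far on this position. On a saturated chain carbon, two bonds along the chain from an oxygen next to a carbonyl group, the group of 4 heavy atoms (2 carbon, 1 nitrogen, 1 selenium) in place of the group of 3 heavy atoms (1 carbon, 1 nitrogen, 1 selenium) does not separate compound 2 from compound 4 in this read-out, so this position accepts the change without a step beyond the scatter. Nothing shown gives a measured reason for this outcome.

Going by these compounds, whether a longer chain at this place would also stay within the scatter of compound 4, at 720 nM, or whether an amine or a carboxylic acid would be tolerated there, remains open. The steps linking compound 2 or compound 4 to compound 1 and compound 3 cannot be read, since each of those pairs differs in more than one place.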